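Moving the amino group while keeping the fluorobenzyl arm

The source may hold more compounds than are shown below. What is called first, only, known or untested is meant among the compounds shown, and "the series" means these compounds.

Compound 1 `Nc1ccc(/C=C2\SC(=O)N(Cc3cccc(Cl)c3)C2=O)cc1`: 24000 nM in a functional assay on HeLa cells (Homo sapiens) for cytotoxicity, read by cell counting, with a stated time of 4 days; on this read-out lower numbers stand for stronger inhibition and higher numbers for weaker inhibition
Compound 2 `Nc1cccc(/C=C2\SC(=O)N(Cc3cccc(F)c3)C2=O)c1`: the limit > 250000 nM in this assay
Compound 3 `Nc1cccc(/C=C2\SC(=O)N(Cc3ccccc3)C2=O)c1`: the limit > 250000 nM in this assay

Among the compounds with values here, compound 2 stands at a limit of this assay and not at a number, and the only other value it can be set against is a limit as well, namely (the limit of > 250000 nM in this assay, at which 2 of the 3 values shown sit). Within the data shown here, the one measured step touching it, a step that the two limits leave unreadable from compound 2 to compound 3, brings hydrogen in place of fluoro on an aromatic carbon, and its size cannot be read from two limits. Compound 4 `Nc1ccc(/C=C2\SC(=O)N(Cc3cccc(F)c3)C2=O)cc1` differs from compound 2 by 4-aminophenyl in place of 3-aminophenyl on a double-bonded chain carbon bound to a double-bonded ring carbon. Among the measured compounds shown here, no measured step follows this change on its own. Compound 1 carries the 4-aminophenyl and returns a number in this assay, while compound 2 and compound 3 carry the 3-aminophenyl, though compound 1 also differs from compound 4 in the group on the benzyl ring, so the comparison is indirect. The step of an at least 6.2-fold lower number from compound 2 to compound 4 (0.79 log units; beyond the scatter) is therefore expected to be a gain that carries compound 4 off the limit. Compound 4 is estimated at 40000 nM, within a range of 12000 nM to 150000 nM.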

Compound 4, half-maximal inhibitory concentration: 250000 nM
Beside the measured number, compound 4's estimate is 6.3-fold (0.80 log units) below it; measured number outside the range, above it.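

With 4-aminophenyl held fixed, fluoro in place of chloro on an aromatic carbon gives a 10-fold higher number from compound 1 to compound 4 (1.02 log units; beyond the scatter) in this assay. The number returned by compound 1 therefore does not follow from the 4-aminophenyl alone, since the chloro-to-fluoro change on the benzyl ring separates it from compound 4. With the fluorobenzyl arm, 4-aminophenyl in place of 3-aminophenyl on a double-bonded chain carbon bound to a double-bonded ring carbon gives a number no higher from compound 2 to compound 4 (the limit leaves the size open). The size of this step stays unreadable, as do the other steps touching the limit, because compound 2 stands at a limit of the assay: the limit of > 250000 nM in this assay, at which 2 of the 4 values shown sit.

Still open, as far as these compounds go, is whether the 4-aminophenyl brings any gain over the 3-aminophenyl when the benzyl ring carries chloro. Also open, from the compounds shown here alone, is how bromo in place of chloro on that aromatic carbon would read.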